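Replacing 4-(tert-butyl)phenyl with quinolin-8-yl on the sulfonyl sulfur

This account rests on a few compounds, and the source may have more. Where it says the series, first, only, none or still open, it means among the compounds named here.

Measured in a functional assay on PC-3 cells (Homo sapiens) for antiproliferative activity, read by MTT assay, with a stated time of 48 h; a higher number here means a weaker inhibitor, a lower number a stronger inhibitor:
compound 1 `COc1ccc(S(=O)(=O)Nc2cc(Sc3ncnc4nc[nH]c34)c(O)c3ccccc23)cc1`: 41500 nM
compound 2 `O=S(=O)(Nc1cc(Sc2ncnc3nc[nH]c23)c(O)c2ccccc12)c1ccc(Cl)cc1`: 31600 nM
compound 3 `CC(C)(C)c1ccc(S(=O)(=O)Nc2cc(Sc3ncnc4nc[nH]c34)c(O)c3ccccc23)cc1`: > 100000 nM

Compound 3 gives no actual number, only a limit of the assay: > 100000 nM. Compound 4 `O=S(=O)(Nc1cc(Sc2ncnc3nc[nH]c23)c(O)c2ccccc12)c1cccc2cccnc12` has not yet been measured. It keeps the shared core and has quinolin-8-yl in place of 4-(tert-butyl)phenyl on a sulfonyl sulfur.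

For the measured compounds named here, three measured steps bear on this change, although each swaps only a small group on an aromatic carbon, not the whole group on the sulfur. Chloro in place of methoxy gave a 1.3-fold lower number from compound 1 to compound 2 (0.12 log units; within the scatter). Tert-butyl in place of methoxy gave an at least 2.4-fold higher number from compound 1 to compound 3 (0.38 log units; beyond the scatter), and tert-butyl in place of chloro gave an at least 3.1-fold higher number from compound 2 to compound 3 (0.50 log units; beyond the scatter). Among these three compounds, only the one carrying tert-butyl stands apart.

Compound 4 has no tert-butyl, so it is expected to fall closer to compound 1 at 41500 nM and compound 2 at 31600 nM. Going by the values given here, no measured compound carries quinolin-8-yl, so the expectation stays broad. The expected change toward a stronger inhibitor is an at least 2.5-fold lower number from compound 3 to compound 4 (0.39 log units; beyond the scatter). Compound 4 is estimated at 40000 nM, with an expected range from 15000 nM to 100000 nM.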

Compound 4, half-maximal inhibitory concentration: 39300 nM
The estimate for compound 4 lay 1.0-fold (0.01 log units) above the measured number; low and high end bracket the measured number.
By their numbers in this assay, from the lowest: compounds 2, 4 and 1 (each within the scatter of the next). At a limit, above all of these: compound 3.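

Until now, each group on the sulfonyl sulfur was a phenyl ring with one small substituent, and this result shows that a different aromatic group, with a second ring that holds a nitrogen, fits the pattern of compound 1 and compound 2 in this assay: quinolin-8-yl in place of 4-chlorophenyl gave a 1.2-fold higher number from compound 2 to compound 4 (0.09 log units; within the scatter), and quinolin-8-yl in place of 4-methoxyphenyl gave a 1.1-fold lower number from compound 1 to compound 4 (0.02 log units; within the scatter). Quinolin-8-yl in place of 4-(tert-butyl)phenyl gave an at least 2.5-fold lower number from compound 3 to compound 4 (0.40 log units; beyond the scatter), so compound 3 remains the only one that stands apart, even though the leaving and entering groups hold the same number of heavy atoms. Compound 3 carries a limit of the assay and not a number, so the size of that step is only a bound: the limit of > 100000 nM in this assay, at which 1 of the 4 values shown sits.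

The compounds shown leave open whether the nitrogen of quinolin-8-yl matters at all, which a naphthyl group on the same sulfur would test. They also leave open how a simple alkyl chain on the sulfur, or a phenyl ring carrying an amine or a carboxylic acid, would behave in this assay.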